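A few compounds are considered here, and "the series" means these few. Any claim that something is new, unique, unknown or untested is made for them only; others in the source may bear on it.

Measured so far in a functional assay (aorta) with Rattus norvegicus as the target; a higher number here means a weaker inhibitor, a lower number a stronger inhibitor:
Compound 1 `CC(C)(C)NCCCOc1ccc(S(=O)(=O)c2c(C(C)(C)C)cn3ccccc23)cc1`: 443 nM
Compound 2 `CCCCN(CCCC)CCCOc1ccc(S(=O)(=O)c2c(C(C)(C)C)cn3ccccc23)cc1`: 51.9 nM

Of these two, compound 2 has the lower number, at 51.9 nM. Compound 3 `CCCCN(CCCC)CCCOc1ccc(S(=O)(=O)c2c(CC)cn3ccccc23)cc1` departs from it by a single change: ethyl in place of tert-butyl on an aromatic carbon. Among the measured compounds shown here, no measured step touches that aromatic carbon. For the measured compounds named here, the only step available, an 8.5-fold lower number from compound 1 to compound 2 (0.93 log units; beyond the scatter), puts dibutylamino in place of (tert-butyl)amino on a saturated chain carbon, elsewhere in the molecule. It shows that one change in this pair moved the number beyond the scatter, but it gives no direction for the new change. A step no larger than that one is therefore expected, in either direction, and possibly none beyond the scatter. The expected change is a 1.2-fold lower number from compound 2 to compound 3 (0.06 log units; within the scatter). For compound 3 the estimated value is 45 nM, with an expected range of 12 nM to 170 nM.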

Compound 3, half-maximal inhibitory concentration: 31.3 nM
Compound 3: the middle estimate sits 1.4-fold (0.16 log units) above what was measured; the measured number falls inside the stated range.
By their numbers in this assay, from the lowest: compounds 3 and 2 (each within the scatter of the next); then compound 1.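

At this aromatic carbon of the five-membered ring, the first change seen in this assay, ethyl in place of tert-butyl, gives a 1.7-fold lower number from compound 2 to compound 3 (0.22 log units; within the scatter). With the dibutylamino chain held fixed, the position therefore accepts the smaller ethyl with no difference that can be told from the scatter, whereas the change at the amine, an 8.5-fold lower number from compound 1 to compound 2 (0.93 log units; beyond the scatter), lies beyond it. Nothing at hand speaks to what lies behind this result.

As far as these compounds go, it remains open how methyl, isopropyl or phenyl on this aromatic carbon would read in this assay, so the ethyl and tert-butyl pair does not yet define how much room for change this position allows. Also open, from the compounds shown here alone, is whether ethyl would read the same alongside the (tert-butyl)amino chain of compound 1, since both compounds in this pair carry dibutylamino.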